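The compounds below may be only part of what the source reports. "The series", "measured", "known", "first", "only" and "open" are said of these compounds alone.

In a functional assay on MGC-803 cells (Homo sapiens) for inhibition, read by MTT assay, with a stated time of 72 h (a lower number here means a stronger inhibitor, a higher number a weaker inhibitor), compound 1 `C#CCSc1nc(Nc2ccccc2Cl)c(C#N)c(-c2ccccc2)n1` gives 52800 nM, compound 2 `N#Cc1c(Nc2ccccc2Cl)nc(SCc2cn(Cc3ccccc3Cl)nn2)nc1-c1ccccc1` gives 4640 nM, and compound 3 `N#Cc1c(Nc2ccc(Cl)cc2)nc(SCc2cn(Cc3ccccc3Cl)nn2)nc1-c1ccccc1` gives 5850 nM. Compound 3 thus stands second highest of the three numbers; its nearest neighbour is reached by a 1.3-fold higher number from compound 2 to compound 3 (0.10 log units; within the scatter), while compound 1 lies further off, beyond the scatter. Compound 4 `Cc1cccc(Nc2nc(SCc3cn(Cc4ccccc4Cl)nn3)nc(-c3ccccc3)c2C#N)c1` differs from compound 3 by 3-methylphenyl in place of 4-chlorophenyl on a nitrogen on an aromatic ring. Going by the values given here, the one measured step at this site, a 1.3-fold higher number from compound 2 to compound 3 (0.10 log units; within the scatter), exchanged one chlorophenyl for another and stayed within the scatter; no measured pair exchanges chlorine for methyl on this ring. One therefore expects no step beyond the scatter in this assay, namely a 1.1-fold lower number from compound 3 to compound 4 (0.03 log units; within the scatter). Compound 4 is estimated at 5500 nM, with a range from 2500 nM to 12000 nM.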

Compound 4, half-maximal inhibitory concentration: 16200 nM
Compound 4: the middle estimate sits 2.9-fold (0.47 log units) below what was measured; measured number above the stated range.
By their numbers in this assay, from the lowest: compounds 2 and 3 (each within the scatter of the next); then compound 4; then compound 1.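

In this assay the group on this nitrogen now proves to matter: the two chlorophenyl compounds had stayed within the scatter of each other, but 3-methylphenyl brings a 2.8-fold higher number from compound 3 to compound 4 (0.44 log units; beyond the scatter) and a 3.5-fold higher number from compound 2 to compound 4 (0.54 log units; beyond the scatter) as modest steps in the weaker direction. The nitrogen substituent therefore tolerates moving the chlorine without a step beyond the scatter, yet not this exchange for 3-methylphenyl. Nothing available explains this step and the account stops at the numbers.

The compounds shown leave open whether the methyl group itself or its place on the ring carries the step. They also leave open how a methoxy group, a fluorine or a carboxylic acid on this ring would compare.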